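A few compounds are considered here, and "the series" means these few. Any claim that something is new, unique, unknown or untested is made for them only; others in the source may bear on it.

Working notes on the series

Compound 1 `COc1cccc(-c2nc3cc(C)ccc3c(=O)[nH]2)c1`, compound 2 `Cc1ccc2c(=O)[nH]c(-c3cccc(F)c3)nc2c1` and compound 3 `Cc1ccc2nc(-c3cccc(OC(F)(F)F)c3)[nH]c(=O)c2c1` share one core and differ only on the pendant aromatic ring. In a functional assay on HCT-15 cells (Homo sapiens) for cytotoxicity, read by MTT assay, with a stated time of 2 days (on this read-out higher numbers stand for weaker inhibition and lower numbers for stronger inhibition), compound 1 gives 4850 nM. In this assay compound 2 gives 14400 nM, the highest of the two numbers available. Compound 3 reaches only the assay limit > 50000 nM in this assay. For the measured compounds named here, the single sized step is a 3.0-fold higher number from compound 1 to compound 2 (0.47 log units; beyond the scatter), a modest move. Compound 4 `Cc1ccc2c(=O)[nH]c(-c3cccc(C(F)(F)F)c3)nc2c1` is the next analogue; its difference from compound 2 is trifluoromethyl in place of fluoro on an aromatic carbon. Going by the values given here, only that step bears on it, and compound 3 sits at the limit (the limit of > 50000 nM in this assay, at which 1 of the 3 values shown sits), so no second step can be sized. A modest weakening is expected, with real chance of another limit. Compound 4 is estimated at 35000 nM, between 12000 nM and 100000 nM, an expected step of a 2.4-fold higher number from compound 2 to compound 4 (0.39 log units; beyond the scatter).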

Compound 4, half-maximal inhibitory concentration: > 50000 nM
Compound 4 ended at the assay's limit; the forecaster's own chance of this, stated with the estimate: 35%; middle value at least 1.4-fold (0.15 log units) away from the limit.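

Trifluoromethyl in place of fluoro, on an aromatic carbon meta to a large group, gives an at least 3.4-fold higher number from compound 2 to compound 4 (0.54 log units; beyond the scatter). Set against methoxy at the same place, it gives an at least 10-fold higher number from compound 1 to compound 4 (1.01 log units; beyond the scatter), the only step in the series rated large. Compound 3 and compound 4 both sit at a limit of the assay rather than at a number, so no step between them can be read: the limit of > 50000 nM in this assay, at which 2 of the 4 values shown sit.

Still open, as far as these compounds go, is whether an amine or a carboxylic acid at this position would give a lower number than methoxy. From the compounds shown here alone, how far compound 3 and compound 4 lie beyond the limit also remains unknown.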